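From compound 1 to compound 3: one group exchanged

The source may report more compounds than this note shows. Statements on the series, on what has been measured and on what is new or still open speak of the compounds shown alone.

Compound 1 `Cc1ccnc(OC(c2ccc(C(F)(F)F)cc2)C2CCN(C(C)CCNC(=O)c3c(Cl)cncc3Cl)CC2)c1`: 33600 nM
Compound 2 `CCO/N=C(/c1ccc(Br)cc1)C1CCN(C(C)CCN(C)C(=O)c2c(C)cc[n+]([O-])c2C)CC1`: > 182000 nM

Going by the values given here, in an ADME assay on PBMC cells (Homo sapiens) for cytotoxicity (on this read-out higher numbers stand for lower toxicity in this test and lower numbers for higher toxicity in this test), compound 1 gives 33600 nM, the only exact number so far. Compound 2 gives > 182000 nM, which is a limit of the assay and not a number.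

Compound 3 `CC(CCNC(=O)c1c(Cl)cncc1Cl)N1CCC(C(Oc2cccc(Cl)n2)c2ccc(C(F)(F)F)cc2)CC1` keeps the core of compound 1 but carries 6-chloropyridin-2-yl in place of 4-methylpyridin-2-yl on an oxygen on a saturated carbon. Among the compounds with values here, no measured pair shows the effect of this exchange, so no change beyond the usual scatter is expected in this assay. The expected 1.2-fold lower number from compound 1 to compound 3 (0.08 log units; within the scatter) is therefore small. Compound 3 is estimated at 28000 nM, with an expected range from 11000 nM to 70000 nM.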

Compound 3, half-maximal cytotoxic concentration: > 32500 nM
Compound 3 ended at the assay's limit; the forecaster's own chance of this, stated with the estimate: 10%; middle value at least 1.1-fold (0.06 log units) away from the limit.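

Compound 3 ended at a limit of the assay, which is not a number, so no step from compound 1 to compound 3 can be read: the limit of > 32500 nM in this assay, at which 1 of the 3 values shown sits.

As far as these compounds go, whether 6-chloropyridin-2-yl in place of 4-methylpyridin-2-yl changes the result in this assay remains open.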